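This account rests on a few compounds, and the source may have more. Where it says the series, first, only, none or still open, it means among the compounds named here.

Compound 1, `CC(=O)Nc1ccc(S(=O)(=O)NNC(=O)c2cccnc2Nc2ccc(Cl)cc2)cc1`, and compound 2, `O=C(NNS(=O)(=O)c1ccc(F)cc1)c1cccnc1Nc1ccc(Cl)cc1Cl`, share a core in which a pyridine carboxamide is joined through a hydrazide to a sulfonyl group. In a functional assay on M14 cells (Homo sapiens) for antiproliferative activity (on this read-out higher numbers stand for lower toxicity in this test and lower numbers for higher toxicity in this test), compound 1 gives only a limit, > 100000 nM. Compound 2 likewise gives only a limit in this assay, > 100000 nM. So compound 1 stands where every value shown stands, at the assay limit, and the limit of > 100000 nM in this assay, at which 2 of the 2 values shown sit, is all the evidence available. Compound 3, `O=C(NNS(=O)(=O)c1ccc(Cl)cc1Cl)c1cccnc1Nc1ccc(Cl)cc1`, is reached from compound 1 by one change: 2,4-dichlorophenyl in place of 4-acetamidophenyl on a sulfonyl sulfur. Going by the values given here, no measured step compares two compounds that differ in one place, so the size of this change is unknown; the expectation is no step beyond the scatter, as a step that the limit leaves unreadable from compound 1 to compound 3. Compound 3 is therefore estimated at 120000 nM, between 30000 nM and 400000 nM, most likely again reported as a limit.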

Compound 3, concentration lethal to 50% of the cells: 79400 nM
Compound 3: the middle estimate sits 1.5-fold (0.18 log units) above what was measured, and the stated range covers the measured number.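

Compound 3 is the only compound shown that gives a number rather than a limit in this assay, so a change on the sulfonyl sulfur can bring a reading inside the measurable range. Replacing 4-acetamidophenyl with 2,4-dichlorophenyl gives an at least 1.2-fold lower number from compound 1 to compound 3 (0.10 log units; that floor lies within the scatter). That figure is only a floor, and the true size of the step cannot be read because compound 1 stands at a limit shared with another compound: the limit of > 100000 nM in this assay, at which 2 of the 3 values shown sit.

The compounds shown do not separate the effect of removing the acetamide from that of adding the two chlorines. Also open, as far as these compounds go, is whether a plain phenyl, or a phenyl carrying an amine or a carboxylic acid, on the same sulfonyl sulfur would give a lower number.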